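A few compounds are considered here, and "the series" means these few. Any claim that something is new, unique, unknown or untested is made for them only; others in the source may bear on it.

Compound 1 `Cc1c(Cl)cccc1CCCCOc1ccc(C#Cc2cccc3c(CCCC(=O)O)c(C)n(CC(=O)O)c23)cc1` is the strongest inhibitor among the three compounds measured: in a functional assay on HEK293 cells for antagonist activity at cysteinyl leukotriene receptor 2 (Homo sapiens), read by fluorescence and calcium flux, with stated times of 30 min and 1 h (a higher number here means a weaker inhibitor, a lower number a stronger inhibitor), compound 1 gives 0.88 nM. Its two measured neighbours differ from it only in the length of the acid chain on the aromatic nitrogen. Compound 2 `Cc1c(Cl)cccc1CCCCOc1ccc(C#Cc2cccc3c(CCCC(=O)O)c(C)n(CCC(=O)O)c23)cc1` gives 22 nM in this assay, and compound 3 `Cc1c(Cl)cccc1CCCCOc1ccc(C#Cc2cccc3c(CCCC(=O)O)c(C)n(CCCCC(=O)O)c23)cc1` gives 30 nM. The steps are large: a 25-fold higher number from compound 1 to compound 2 (1.40 log units; beyond the scatter) and a 34-fold higher number from compound 1 to compound 3 (1.53 log units; beyond the scatter), whereas a 1.4-fold higher number from compound 2 to compound 3 (0.13 log units; within the scatter).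

Compound 4 `Cc1c(Cl)cccc1CCCCOc1ccc(C#Cc2cccc3c(CC(=O)O)c(C)n(CC(=O)O)c23)cc1` changes a different chain. Relative to compound 1 the alteration is carboxy in place of 2-carboxyethyl on a saturated chain carbon bound to an aromatic carbon; the same difference, cut one bond further out, reads as 3-carboxypropyl to carboxymethyl. For the measured compounds named here, no measured step touches this chain, so no step bears on it directly. What the measured steps do show is that shortening or lengthening an acid chain by a single carbon at the nitrogen already shifts the number far beyond the scatter, as seen from compound 1 to compound 2 and from compound 1 to compound 3. A change of two carbons at the other acid chain is therefore expected to move the number as well, most likely upward, and the estimated step is a 10-fold higher number from compound 1 to compound 4 (1.01 log units; beyond the scatter). In this assay compound 4 is expected to give about 9 nM, within a range of 1.2 nM to 70 nM.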

Compound 4, half-maximal inhibitory concentration: 0.89 nM
Beside the measured number, compound 4's estimate is 10-fold (1.00 log units) above it; measured number outside the range, below it.
By their numbers in this assay, from the lowest: compounds 1 and 4 (each within the scatter of the next); then compounds 2 and 3 (each within the scatter of the next).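

In this assay, cutting the chain on the aromatic carbon from 3-carboxypropyl to carboxymethyl leaves the number in place, with a 1.0-fold higher number from compound 1 to compound 4 (0.00 log units; within the scatter). This chain therefore behaves unlike the acid chain on the aromatic nitrogen, where lengthening from compound 1 brought a 25-fold higher number from compound 1 to compound 2 (1.40 log units; beyond the scatter) and a 34-fold higher number from compound 1 to compound 3 (1.53 log units; beyond the scatter), so among these compounds the sensitivity to chain length belongs to the nitrogen chain and not to this one. The same change also stays small where it was read on the nitrogen chain, and the two steps agree: the same change on two cores in this assay, a 1.4-fold higher number (0.13 log units; within the scatter) from compound 2 to compound 3 and a 1.0-fold lower number (0.00 log units; within the scatter) from compound 4 to compound 1, 1.4-fold (0.14 log units) apart, within the scatter of two such steps.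

From the compounds shown here alone, what a primary amide or a plain alkyl chain would do in place of the carboxylic acid on the chain bound to an aromatic carbon stays open, as does a longer chain ending in that acid. Also open, going by these compounds, is whether the shorter carboxymethyl at this place would be as well accepted with the longer acid chains on the aromatic nitrogen carried by compound 2 and compound 3.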